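Swapping the aryl group on a small anti-writhing scaffold

A few compounds are considered here, and "the series" means these few. Any claim that something is new, unique, unknown or untested is made for them only; others in the source may bear on it.

Compound 1 `O=C1N=C(C2C(=O)c3ccccc3C2=O)CC(c2ccccc2)N1` and compound 2 `CN(C)c1ccc(C2CC(C3C(=O)c4ccccc4C3=O)=NC(=O)N2)cc1` share one core and differ only in a dimethylamino in place of hydrogen on an aromatic carbon. In a functional assay on the whole organism for inhibition, with Mus musculus as the target, in the writhing test, with a stated time of 15 min, at a dose of 10 mg/kg (a higher number here means more inhibition at the dose given (going by the name of the read-out), a lower number less inhibition), compound 1 gives 31%, while compound 2 gives 52%. Compound 2 therefore stands highest of the two numbers shown; the only measured step, a number 21 percentage points higher from compound 1 to compound 2 (beyond the scatter), lies beyond the scatter and is modest in size.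

Compound 3 `O=C1N=C(C2C(=O)c3ccccc3C2=O)CC(c2ccccc2O)N1` is not yet measured. It differs from compound 2 by 2-hydroxyphenyl in place of 4-(dimethylamino)phenyl on a saturated ring carbon. Among the compounds with values here, the dimethylamino whose arrival gave the gain of a number 21 percentage points higher from compound 1 to compound 2 (beyond the scatter) is now gone, so that measured step bears directly on this one and points toward a loss of similar size; the entering hydroxyl has no measured counterpart here, so its own contribution is unknown. For compound 3 a downward step of about a number 16 percentage points lower from compound 2 to compound 3 (beyond the scatter) is therefore expected, landing close to where compound 1 stands. The estimate for compound 3 in this assay is 36%, with a range from 18% to 56%.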

Compound 3, a percentage reported as inhibition, in the whole organism at one dose (the size of the read-out at that dose, not a potency): 37%
Beside the measured number, compound 3's estimate is 1 percentage points below it; the range from low to high includes it.
By their numbers in this assay, from the lowest: compounds 1 and 3 (each within the scatter of the next); then compound 2.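

In this assay, the step of a number 6 percentage points higher from compound 1 to compound 3 (within the scatter) means that hydroxy in place of hydrogen on an aromatic carbon leaves no readable change, so the 2-hydroxyphenyl and plain phenyl groups cannot be told apart at this position. The change from 4-(dimethylamino)phenyl to 2-hydroxyphenyl on the saturated ring carbon gives a number 15 percentage points lower from compound 2 to compound 3 (beyond the scatter) and is beyond the scatter, so among these three compounds only the one carrying 4-(dimethylamino)phenyl stands clear of the others. No measured property of these compounds accounts for the difference, so the numbers record what happens at this position but not the reason.

The step between compound 2 and compound 3 changes both the group and its place on the aromatic ring, so the compounds shown cannot separate the effect of the group from the effect of where it sits. A 2-(dimethylamino)phenyl or 4-hydroxyphenyl group would help to separate the two, while a 4-aminophenyl or 4-(diethylamino)phenyl group would show how much the gain depends on the groups carried by the nitrogen.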